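Pyrimidinyl for tetrazolyl on the thioether sulfur

The compounds below may be only part of what the source reports. "The series", "measured", "known", "first", "only" and "open" are said of these compounds alone.

Working notes on a small series built on one shared core. Compound 1 `O=C(CSc1ncccn1)N/N=c1/scc(-c2ccc([N+](=O)[O-])cc2)n1-c1ccccc1` belongs to the set, but in a functional assay on C6 cells (Rattus norvegicus) for cytotoxicity, read by MTT assay, with a stated time of 24 h (a higher number here means a weaker inhibitor, a lower number a stronger inhibitor), compound 1 gives "not determined" (no result reported), so it contributes no number. Among the measured compounds shown here, compound 2 `Cc1ccc(-c2cs/c(=N/NC(=O)CSc3nnnn3C)n2-c2ccccc2)cc1` is the only member with a measured value: in this assay compound 2 gives 36.3 ug/mL. For the measured compounds named here, with a single number in hand, compound 2 stands alone; there is no second measured compound to place it against, and no step between measured compounds is available.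

Compound 3 `Cc1ccc(-c2cs/c(=N/NC(=O)CSc3ncccn3)n2-c2ccccc2)cc1` is the entry still to be measured. It differs from compound 2 in one place: pyrimidin-2-yl in place of 1-methyl-1H-tetrazol-5-yl on a sulfur whose other neighbour is a saturated chain carbon. Nothing in the measured set tells the direction of this exchange. The expected step in this assay is a 1.0-fold lower number from compound 2 to compound 3 (0.00 log units; within the scatter), taken as none beyond the usual scatter. On that basis compound 3 is estimated at 36 ug/mL, with an expected range from 15 ug/mL to 85 ug/mL.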

Compound 3, half-maximal inhibitory concentration: 85 ug/mL
Beside the measured number, compound 3's estimate is 2.4-fold (0.37 log units) below it; the range from low to high includes it.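

In this assay, pyrimidin-2-yl in place of 1-methyl-1H-tetrazol-5-yl on a sulfur gives a 2.3-fold higher number from compound 2 to compound 3 (0.37 log units; beyond the scatter), so the group at this position can move the read-out beyond the usual scatter, and this exchange moves it towards a weaker inhibitor. The exchange keeps the size of the group as counted, with 6 heavy atoms and no net charge on each side, while one five-membered aromatic ring with 4 hetero atoms and 4 hydrogen-bond acceptors gives way to one six-membered aromatic ring with 2 hetero atoms and 2 hydrogen-bond acceptors. No measurement in hand accounts for the step.

Which of these counted differences matters, if any, stays open, since one pair cannot separate them and the step is known only on the core of compound 2. Also open, from the compounds shown here alone, is where a phenyl group, or a longer chain carrying an amine or a carboxylic acid, on the same sulfur would read relative to compound 2 and compound 3.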